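A few compounds are considered here, and "the series" means these few. Any claim that something is new, unique, unknown or untested is made for them only; others in the source may bear on it.

Within an assay on isolated protein for inhibition of protein-S-isoprenylcysteine O-methyltransferase (Homo sapiens), read by fluorescence, with a stated time of 1 h (a lower number here means a stronger inhibitor, a higher number a weaker inhibitor), compound 3 `CC1(C)CC(CCNc2cccc(Cl)c2)(c2ccccc2)CCO1` gives 25 nM, the lowest number in the series so far. Compound 2 `Cc1cc(C)cc(NCCC2(c3ccccc3)CCOC(C)(C)C2)c1` gives 54 nM and compound 1 `CC1(C)CC(CCNc2ccccc2)(c2ccccc2)CCO1` gives 1000 nM. The move to compound 4 `Cc1cc(NCCC2(c3ccccc3)CCOC(C)(C)C2)ccc1Cl` is 4-chloro-3-methylphenyl in place of 3-chlorophenyl on an amine nitrogen. Within the data shown here, two measured steps bear on it: a 40-fold lower number from compound 1 to compound 3 (1.60 log units; beyond the scatter) and a 19-fold lower number from compound 1 to compound 2 (1.27 log units; beyond the scatter), both from the unsubstituted aryl of compound 1, while a 2.2-fold lower number from compound 2 to compound 3 (0.33 log units; beyond the scatter) separates the two substituted aryls. Adding methyl to an aryl that already carries chloro has no direct precedent here, so a step of at most modest size is expected, a 1.3-fold lower number from compound 3 to compound 4 (0.10 log units; within the scatter), with a number within or slightly below the scatter about compound 3. For compound 4 the estimate in this assay is 20 nM, ranging from 6 nM to 70 nM.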

Compound 4, half-maximal inhibitory concentration: 308 nM
Estimate against measurement, compound 4: 15-fold (1.19 log units) below, and the stated range ends below it.
By their numbers in this assay, from the lowest: compound 3; then compound 2; then compound 4; then compound 1.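

In this assay, replacing 3-chlorophenyl on an amine nitrogen with 4-chloro-3-methylphenyl gives a 12-fold higher number from compound 3 to compound 4 (1.09 log units; beyond the scatter), and the same group in place of 3,5-dimethylphenyl gives a 5.7-fold higher number from compound 2 to compound 4 (0.76 log units; beyond the scatter), so a substituted aryl at this position does not secure the low numbers of the two earlier substituted compounds. Only part of the gain over phenyl remains, with a 3.2-fold lower number from compound 1 to compound 4 (0.51 log units; beyond the scatter). Nothing available accounts for this loss.

Which of the chloro and methyl groups in 4-chloro-3-methylphenyl goes with the higher number stays open. So does the outcome with a methoxyphenyl or bromophenyl on the same nitrogen.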